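Amide nitrogen substituent and cytotoxicity in Huh-7 cells

The source may report more compounds than this note shows. Statements on the series, on what has been measured and on what is new or still open speak of the compounds shown alone.

Compound 1 `O=C(Nc1ccccc1)c1c(NO)cc(-c2ccc(F)cc2)oc1=O`: 10300 nM
Compound 2 `O=C(Nc1ccc(F)cc1)c1c(NO)cc(-c2ccccc2)oc1=O`: > 20000 nM
Compound 3 `Cc1ccc(NC(=O)c2c(NO)cc(-c3ccc(C)cc3)oc2=O)cc1`: > 20000 nM

Of the compounds shown here, three sharing one core have been tested in an ADME assay on Huh-7 cells (Homo sapiens) for cytotoxicity, read by a luciferase reporter and WST assay, with a stated time of 3 days; on this read-out higher numbers stand for lower toxicity in this test and lower numbers for higher toxicity in this test. Compound 1 gives 10300 nM in this assay. Compound 2 gives > 20000 nM in this assay, which is a limit of the measurement and not a number. Compound 3 likewise gives > 20000 nM in this assay, again a limit rather than a number. Compound 2 therefore sits at the limit of > 20000 nM in this assay, at which 2 of the 3 values shown sit, and nothing more exact about it is known.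

The next compound, compound 4 `CCCNC(=O)c1c(NO)cc(-c2ccccc2)oc1=O`, has not yet been measured. It differs from compound 2 in one place: propyl in place of 4-fluorophenyl on an amide-type nitrogen. Going by the values given here, with no measured pair of this kind to lean on, the expectation for this change is a step of no clear size in either direction, most likely again nothing beyond the scatter and a reading that stays at the limit. Compound 4 is thus estimated at 20000 nM, within 8000 nM to 40000 nM, which means an expected step of a number no higher from compound 2 to compound 4 (the limit leaves the size open).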

Compound 4, half-maximal cytotoxic concentration: > 20000 nM
Compound 4 ended at the assay's limit (the forecaster's own chance of this, stated with the estimate: 60%); the middle value lies on the limit itself.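

In this assay compound 4 gives > 20000 nM, a limit and not a number. Going by these compounds alone, compound 2 gives > 20000 nM, also a limit, so no step between these two compounds can be read. Going by these compounds, what stays open is whether propyl and 4-fluorophenyl on the amide-type nitrogen differ at all in this read-out.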